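A few compounds are considered here, and "the series" means these few. Any claim that something is new, unique, unknown or untested is made for them only; others in the source may bear on it.

Compound 3 `Cc1nc(N2CCCC2)c2nnn(-c3ccc(C(C)C)cc3Br)c2n1` is the middle point of the three values recorded so far. In an in vitro assay on 293-EBNA cells for binding affinity to corticotropin-releasing factor receptor 1 (Homo sapiens) (on this read-out lower numbers stand for stronger inhibition and higher numbers for weaker inhibition), compound 3 gives 194 nM. Compound 1 `COCCNc1nc(C)nc2c1nnn2-c1c(C)cc(C)cc1C` sits on the weaker side of it, giving 1200 nM in this assay, while compound 2 `CCCC(C)Nc1nc(C)nc2c1nnn2-c1c(C)cc(C)cc1C` is the strongest of the three, with 7.1 nM in this assay. Compound 4 `COCCNc1nc(C)nc2c1nnn2-c1ccc(C(C)C)cc1Br` has not yet been measured in this assay. It differs from compound 3 in one place: (2-methoxyethyl)amino in place of pyrrolidin-1-yl on an aromatic carbon.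

For the measured compounds named here, no measured step swaps a pyrrolidin-1-yl for a (2-methoxyethyl)amino, so the only guidance comes from the pair of compound 1 and compound 2, where the amine substituent was also the sole difference. There the step of a 170-fold lower number from compound 1 to compound 2 (2.23 log units; beyond the scatter) shows that, on a shared core, the 1-methylbutyl partner runs far below the 2-methoxyethyl partner. Reading that in reverse, the (2-methoxyethyl)amino that enters in compound 4 is the same group that accompanies the weakest value, so a rise in the number is expected, though its size is uncertain because the group that leaves is not the one that was measured against it. The step from compound 3 is estimated at a 6.2-fold higher number from compound 3 to compound 4 (0.79 log units; beyond the scatter). Compound 4 is therefore expected to give about 1200 nM in this assay, within a range of 300 nM to 5000 nM.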

Compound 4, inhibition constant: 242 nM
Compound 4: middle estimate off by 5.0-fold (0.70 log units), on the high side; the whole stated range lies above it.
By their numbers in this assay, from the lowest: compound 2; then compounds 3 and 4 (each within the scatter of the next); then compound 1.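

In this assay, the carbon next to the ring nitrogen tolerates an exchange of the pyrrolidin-1-yl ring for the open (2-methoxyethyl)amino chain, with a 1.2-fold higher number from compound 3 to compound 4 (0.10 log units; within the scatter), even though the entering group brings one hydrogen-bond donor where the leaving group has none. The earlier pair, with a 170-fold lower number from compound 1 to compound 2 (2.23 log units; beyond the scatter), set 2-methoxyethyl only against 1-methylbutyl on a different core, so it could not show that the 2-methoxyethyl group is on a level with a ring amine of equal heavy-atom count, as it is on the core of compound 3. Nothing available explains why these two groups read alike at this position.

The compounds shown leave open whether the large gap between 1-methylbutyl and 2-methoxyethyl would return on the core of compound 4, since that branched chain appears here only on the core of compound 1. They also leave open how a piperidine ring, a morpholine ring or a longer 3-methoxypropyl chain on the same carbon would compare with pyrrolidin-1-yl and (2-methoxyethyl)amino.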